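Stereochemical inversion of the amide-bearing centre in the series

A few compounds are considered here, and "the series" means these few. Any claim that something is new, unique, unknown or untested is made for them only; others in the source may bear on it.

Measured compounds:
compound 1 `NS(=O)(=O)OC[C@@H]1C[C@@H](n2nnc3c(N[C@H]4CCc5ccccc54)ncnc32)C[C@@H]1O` gives 0.21 nM
compound 2 `NS(=O)(=O)OC[C@@H]1C[C@@H](n2nnc3c(N[C@@H]4c5ccccc5C[C@@H]4O)ncnc32)C[C@@H]1O` gives 2.28 nM
compound 3 `COCC(=O)N[C@H]1Cc2ccccc2[C@H]1Nc1ncnc2c1nnn2[C@@H]1C[C@@H](COS(N)(=O)=O)[C@@H](O)C1` gives 170 nM

All three numbers come from an assay on a protein complex for inhibition of NEDD8 activating enzyme (Homo sapiens), read by HTRF, with a stated time of 2 h, in the presence of a further agent that is not named here; on this read-out higher numbers stand for weaker inhibition and lower numbers for stronger inhibition. Compound 3 stands highest of the three, weakest on this read-out; its nearest neighbour is compound 2, and the step of a 75-fold higher number from compound 2 to compound 3 (1.87 log units; beyond the scatter) lies well beyond the scatter, while an 810-fold higher number from compound 1 to compound 3 (2.91 log units; beyond the scatter) is larger still. The substituent introduced at the saturated ring carbon in compound 3 thus cost a great deal against the unsubstituted compound 1, more than the hydroxy of compound 2 did in an 11-fold higher number from compound 1 to compound 2 (1.04 log units; beyond the scatter).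

Compound 4 `COCC(=O)N[C@@H]1Cc2ccccc2[C@H]1Nc1ncnc2c1nnn2[C@@H]1C[C@@H](COS(N)(=O)=O)[C@@H](O)C1` keeps every atom and bond of compound 3; the difference is the two compounds have the same atoms and bonds and differ only in configuration as drawn: 1 of 5 stereo elements differ; a stereocentre at a saturated ring carbon is drawn S in compound 3 and R in compound 4. Among the compounds with values here, none of the measured steps is a pure stereochemical inversion, so no measured step bears directly on it; the substituent steps only show that this position is sensitive. The direction is therefore open. In this assay compound 4 is expected to give 120 nM, within a wide range of 15 nM to 900 nM, the expected step of a 1.4-fold lower number from compound 3 to compound 4 (0.15 log units; within the scatter) being small but uncertain in sign.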

Compound 4, half-maximal inhibitory concentration: > 10000 nM
Compound 4: only a limit was reported (the forecaster's own chance of this, stated with the estimate: 2%); middle value at least 83-fold (1.92 log units) away from the limit.
By their numbers in this assay, from the lowest: compound 1; then compound 2; then compound 3. At a limit, above all of these: compound 4.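

In this assay compound 4 gives > 10000 nM, which is a limit and not a number. Within the data shown here, the earlier steps showed only that substitution at this saturated ring carbon is costly; the new pair shows that the drawn configuration at this carbon also matters greatly, with an at least 58-fold higher number from compound 3 to compound 4 (1.76 log units; beyond the scatter), and that configuration is the sole change: the fact that compounds 3 and 4 differ only in the configuration as drawn. Against the unsubstituted compound the cost becomes an at least 47000-fold higher number from compound 1 to compound 4 (4.67 log units; beyond the scatter), so the ((methoxymethyl)carbonyl)amino group is compatible with a measured inhibition here only as drawn in compound 3.

On these data alone, whether a free amine or a carboxylic acid at this carbon would respond to the same inversion stays open. As far as these compounds go, the true position of compound 4 beyond its limit also stays open, so both new steps remain bounds.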